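This account rests on a few compounds, and the source may have more. Where it says the series, first, only, none or still open, it means among the compounds named here.

In a functional assay on KYSE-70 cells for antiproliferative activity against KYSE-70 cell line (Homo sapiens), read by MTT assay, with a stated time of 72 h (on this read-out lower numbers stand for stronger inhibition and higher numbers for weaker inhibition), three compounds that share one core have been tested so far. Compound 1 `O=C(Nc1cccc(F)c1)c1cc(=O)[nH]c2cc(F)ccc12` gives > 20000 nM, which is a limit of the assay and not a number. With phenyl in place of the fluoro of compound 1, compound 2 `O=C(Nc1cccc(F)c1)c1cc(=O)[nH]c2cc(-c3ccccc3)ccc12` gives > 20000 nM, again only a limit. For the measured compounds named here, compound 3 `O=C(Nc1cccc(F)c1)c1cc(=O)[nH]c2cc(-c3ccc(F)cc3)ccc12` gives 3300 nM, the only true number available. Compound 4 `CC(=O)c1ccc(-c2ccc3c(C(=O)Nc4cccc(F)c4)cc(=O)[nH]c3c2)cc1` differs from compound 3 by acetyl in place of fluoro on an aromatic carbon, para to a large group, which reads as 4-fluorophenyl to 4-acetylphenyl: acetyl in place of fluoro on an aromatic carbon. The closest evidence comes from the same carbon, where fluoro in place of hydrogen gave an at least 6.0-fold lower number from compound 2 to compound 3 (0.78 log units; beyond the scatter). Swapping fluoro for 4-fluorophenyl gave an at least 6.0-fold lower number from compound 1 to compound 3 (0.78 log units; beyond the scatter). Going by the values given here, both steps show that activity here depends on a small change, but no tested compound carries an acetyl. A modest move toward weaker inhibition is therefore expected, and the expected step is a 1.5-fold higher number from compound 3 to compound 4 (0.18 log units; within the scatter). For compound 4 the estimated value is 5000 nM, with an expected range of 1500 nM to 18000 nM.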

Compound 4, half-maximal inhibitory concentration: > 20000 nM
Compound 4 was reported as a limit; the forecaster's own chance of this, stated with the estimate: 20%; middle value at least 4.0-fold (0.60 log units) away from the limit.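

In this assay, changing 4-fluorophenyl to 4-acetylphenyl gives an at least 6.0-fold higher number from compound 3 to compound 4 (0.78 log units; beyond the scatter), so the gain that came with fluoro on this carbon is not kept when acetyl stands there instead. Of the three groups shown on this carbon (hydrogen, fluoro and acetyl), only fluoro gives a true number, so the picture at this position rests on a single value: the limit of > 20000 nM in this assay, at which 3 of the 4 values shown sit. The steps to compound 4 from compound 1 and from compound 2 cannot be read, as each joins two limits.

Going by these compounds, whether another group on this carbon, such as chloro, methoxy, an amine or a carboxylic acid, would match or improve on compound 3 stays open. On these data alone, neither compound 2 nor compound 4 has a true number, so how these two rank against each other also stays open.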